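The source may hold more compounds than are shown below. What is called first, only, known or untested is meant among the compounds shown, and "the series" means these compounds.

Compounds measured so far:
- compound 1 `CN1[C@@H]2c3[nH]c4ccccc4c3C[C@H]1[C@H](C#N)N1[C@@H](CNC(=O)c3ccc4ccccc4c3)c3[nH]c4ccccc4c3C[C@@H]21`: 1030 nM
- compound 2 `CN1[C@@H]2c3[nH]c4ccccc4c3C[C@H]1[C@H](C#N)N1[C@@H](CNC(=O)c3ccc4ccccc4n3)c3[nH]c4ccccc4c3C[C@@H]21`: 60 nM

In a functional assay on A2780 cells (Homo sapiens) for cytotoxicity, read by MTT assay, with a stated time of 72 h (a higher number here means a weaker inhibitor, a lower number a stronger inhibitor), compound 1 gives 1030 nM, and compound 2 gives 60 nM. For the measured compounds named here, compound 2 thus stands lowest of the two numbers, and the only step available, a 17-fold lower number from compound 1 to compound 2 (1.23 log units; beyond the scatter), separates it from compound 1 by an amount beyond the scatter, with the heteroaromatic group on the carbonyl carbon going with the lower number.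

Compound 3 `CN1[C@@H]2c3[nH]c4ccccc4c3C[C@H]1[C@H](C#N)N1[C@@H](CNC(=O)/C=C/c3cccc(C(F)(F)F)c3)c3[nH]c4ccccc4c3C[C@@H]21` differs from compound 2 in one place: 2-(3-(trifluoromethyl)phenyl)ethenyl in place of quinolin-2-yl on a carbonyl carbon. Going by the values given here, the single measured step bears on this only indirectly. Going from compound 1 to compound 2 exchanged a hydrocarbon aromatic group for one carrying a ring nitrogen and the number fell sharply, so removing that nitrogen-containing ring again, here in favour of a group with no hydrogen-bond acceptor, gives reason to expect the number to move back upward, though the new group is not the same as the one in compound 1, so the size of the reversal is uncertain. Compound 3 is therefore expected to give about 450 nM in this assay, within a range of 120 nM to 1800 nM. The estimated step is a 7.5-fold higher number from compound 2 to compound 3 (0.88 log units; beyond the scatter), that is, a weaker inhibitor than compound 2 but not necessarily as weak as compound 1.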

Compound 3, half-maximal inhibitory concentration: > 10000 nM
Compound 3: only a limit was reported (the forecaster's own chance of this, stated with the estimate: 5%); middle value at least 22-fold (1.34 log units) from the limit.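

For compound 3, this assay yields only a limit, not a number: the limit of > 10000 nM in this assay, at which 1 of the 3 values shown sits.

Placing 2-(3-(trifluoromethyl)phenyl)ethenyl on the carbonyl carbon in place of quinolin-2-yl gives an at least 160-fold higher number from compound 2 to compound 3 (2.22 log units; beyond the scatter), and placing it there in place of naphthalen-2-yl gives an at least 9.7-fold higher number from compound 1 to compound 3 (0.98 log units; beyond the scatter). For the compounds shown here, the earlier pair showed only that two fused aromatic groups at this position can differ widely, whereas these steps show that a group with no ring nitrogen can lie well beyond the level of the naphthalen-2-yl compound. The absence of a ring nitrogen therefore does not by itself set the level, since naphthalen-2-yl also lacks one and still gives a measured number.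

As far as these compounds go, how far compound 3 lies past its limit stays unknown, and the double bond and the trifluoromethyl group enter together, so their separate shares in the change cannot be told apart. Also open, from the compounds shown here alone, is how a phenyl group attached directly to the carbonyl carbon, an unsubstituted 2-phenylethenyl group or a pyridine ring would stand at this position.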